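The source may hold more compounds than are shown below. What is called first, only, known or untested is meant among the compounds shown, and "the series" means these compounds.

Values in a functional assay on A549 cells (Homo sapiens) for antiproliferative activity, read by MTT assay, with a stated time of 72 h; a higher number here means a weaker inhibitor, a lower number a stronger inhibitor:
- Compound 1 `COc1ccc(N2C(=O)COc3ccc(-c4cnc(Cl)c(NS(=O)(=O)c5ccc(F)cc5)c4)cc32)cc1`: 30400 nM
- Compound 2 `O=C1COc2ccc(-c3cccc(NS(=O)(=O)c4ccc(F)cc4)c3)cc2N1c1ccc(Cl)cc1`: 31600 nM
- Compound 3 `O=C1COc2ccc(-c3cccc(NS(=O)(=O)c4ccc(F)cc4)c3)cc2N1C1CC1`: > 40000 nM, a limit of the assay

Within the data shown here, compound 1 lies within the scatter of compound 2, and the only other reading is a limit. Compound 4 `O=C1COc2ccc(-c3cnc(Cl)c(NS(=O)(=O)c4ccc(F)cc4)c3)cc2N1C1CC1` has cyclopropyl in place of 4-methoxyphenyl on an amide-type nitrogen in a ring.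

Among the measured compounds shown here, one measured step bears on this: an at least 1.2-fold higher number from compound 2 to compound 3 (0.10 log units; that floor lies within the scatter), the same kind of change, from 4-chlorophenyl, on another core. That step ends at a limit: the limit of > 40000 nM in this assay, at which 1 of the 3 values shown sits. Going by these compounds, its true size is unknown, so a move to a higher number in this assay is expected, but none beyond the scatter can be firmly predicted.

The expected step is a 1.5-fold higher number from compound 1 to compound 4 (0.17 log units; within the scatter). For compound 4 the estimated value is 45000 nM, with an expected range of 25000 nM to 90000 nM.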

Compound 4, half-maximal inhibitory concentration: 4330 nM
Estimate against measurement, compound 4: 10-fold (1.02 log units) above; measured number below the stated range.
By their numbers in this assay, from the lowest: compound 4; then compounds 1 and 2 (each within the scatter of the next). At a limit, above all of these: compound 3.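

In this assay, cyclopropyl in place of 4-methoxyphenyl on the amide-type nitrogen gives a 7.0-fold lower number from compound 1 to compound 4 (0.85 log units; beyond the scatter). Among these compounds, this is the first step at this position whose size can be read, and it shows that the aryl group is not needed for activity on this core. The step to compound 3 on the other core ends at a limit and cannot be read, so the two cores cannot be compared for this change: the limit of > 40000 nM in this assay, at which 1 of the 4 values shown sits.

Going by these compounds, whether cyclohexyl, an ethyl chain or a chain ending in an amine would give a lower number at this nitrogen remains open. Also open, on these data alone, is whether the lower number with cyclopropyl depends on the core of compound 4.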